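Chain in place of phenyl on the ring nitrogen

This account rests on a few compounds, and the source may have more. Where it says the series, first, only, none or still open, it means among the compounds named here.

The series keeps the core of compound 1 `CN1CCN(c2nc3ccccc3[nH]2)CC1` and varies only the group on its aromatic nitrogen. In a functional assay on ileum for inhibition of histamine H1 receptor (Cavia porcellus) (on this read-out lower numbers stand for stronger inhibition and higher numbers for weaker inhibition), compound 1 gives only a limit, > 3000 nM, and no number. Compound 2 `CCCCCCn1c(N2CCN(C)CC2)nc2ccccc21`, with hexyl on that nitrogen, gives 26 nM in this assay. Compound 3 `CN1CCN(c2nc3ccccc3n2-c2ccccc2)CC1`, with phenyl there, gives 760 nM in this assay. Within the data shown here, of the two numbers known, compound 3 stands highest, the step being a 29-fold higher number from compound 2 to compound 3 (1.47 log units; beyond the scatter). Against the limit of compound 1 the step is an at least 3.9-fold lower number from compound 1 to compound 3 (0.59 log units; beyond the scatter), and that of compound 2 is an at least 110-fold lower number from compound 1 to compound 2 (2.06 log units; beyond the scatter).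

Compound 4 `CCCSCn1c(N2CCN(C)CC2)nc2ccccc21` carries (propylsulfanyl)methyl in place of phenyl on an aromatic nitrogen. The step that bears on it most directly is a 29-fold higher number from compound 2 to compound 3 (1.47 log units; beyond the scatter), here run backwards: an open chain returns in place of the phenyl. The chain is one heavy atom shorter than hexyl and holds a sulfur, so the full reversal is not assumed, but a large lowering of the number is expected. Compound 4 is therefore expected to give about 60 nM in this assay, with a range from 15 nM to 250 nM. That estimate means an expected step of a 13-fold lower number from compound 3 to compound 4 (1.10 log units; beyond the scatter).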

Compound 4, half-maximal inhibitory concentration: 68 nM
Estimate against measurement, compound 4: 1.1-fold (0.05 log units) below; the measured number falls inside the stated range.
By their numbers in this assay, from the lowest: compound 2; then compound 4; then compound 3. At a limit, above all of these: compound 1.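

With (propylsulfanyl)methyl in place of phenyl on the aromatic nitrogen, this assay shows an 11-fold lower number from compound 3 to compound 4 (1.05 log units; beyond the scatter), so the low number at this position is not confined to hexyl: both open chains, in compound 2 and compound 4, lie well under the phenyl of compound 3. A sulfur in the chain is tolerated, but the match with hexyl is not complete: propylsulfanyl in place of pentyl on the saturated chain carbon gives a 2.6-fold higher number from compound 2 to compound 4 (0.42 log units; beyond the scatter), a modest step that leaves compound 2 lowest of the series. Compound 1 gives only a limit, so the step from hydrogen on that nitrogen, an at least 44-fold lower number from compound 1 to compound 4 (1.64 log units; beyond the scatter), is bounded on one side and its true size stays unfixed: the limit of > 3000 nM in this assay, at which 1 of the 4 values shown sits.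

Compound 4 differs from compound 2 in both chain length and the sulfur, so the shown compounds do not separate the two contributions to that modest step. A pentyl chain, a propoxymethyl chain with oxygen in place of the sulfur, and a benzyl group on the same nitrogen would show whether the sulfur, the length or the directly attached aromatic ring of compound 3 governs the number.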